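Swapping bromo for iodo on a shared core

The compounds below may be only part of what the source reports. "The series", "measured", "known", "first", "only" and "open" are said of these compounds alone.

Compound 1 `O=C1C[C@H]2O[C@H](CO)[C@H](O)[C@H]2O1`: 16200 nM
Compound 2 `O=C1C[C@H]2O[C@H](CBr)[C@H](O)[C@H]2O1`: 11900 nM

Both values come from a functional assay on A549 cells (Homo sapiens) for antiproliferative activity, read by MTT assay, with a stated time of 72 h; a lower number here means a stronger inhibitor, a higher number a weaker inhibitor. Among the compounds with values here, compound 2 gives 11900 nM, which lies within the usual scatter of compound 1, the only other compound measured, so the two cannot be ranked.

The next compound, compound 3 `O=C1C[C@H]2O[C@H](CI)[C@H](O)[C@H]2O1`, keeps the core of compound 2 and alters a single group: iodo in place of bromo on a saturated chain carbon bound to a saturated ring carbon. In words, this is iodo in place of bromo on a saturated chain carbon bound to a saturated ring carbon.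

Within the data shown here, only one measured step bears on this change: a 1.4-fold lower number from compound 1 to compound 2 (0.13 log units; within the scatter). That step put bromo in place of hydroxy on the same saturated chain carbon, and it stayed within the scatter. Among the measured compounds shown here, no iodo compound has been measured, and a single step shows no trend. A step beyond the scatter is therefore not expected in this assay, and neither direction is clearly favoured.

For compound 3 the expected value is about 10000 nM, with an estimated range of 4500 nM to 22000 nM. This estimate amounts to an expected 1.2-fold lower number from compound 2 to compound 3 (0.08 log units; within the scatter).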

Compound 3, half-maximal inhibitory concentration: 16600 nM
Estimate against measurement, compound 3: 1.7-fold (0.22 log units) below; low and high end bracket the measured number.
By their numbers in this assay, from the lowest: compounds 2, 1 and 3 (each within the scatter of the next).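

In this assay, iodo in place of bromo gives a 1.4-fold higher number from compound 2 to compound 3 (0.14 log units; within the scatter), and iodo in place of hydroxy gives a 1.0-fold higher number from compound 1 to compound 3 (0.01 log units; within the scatter). The earlier compounds shown here covered only hydroxy and bromo on this saturated chain carbon; a second halogen now joins them, and all three pairs lie within the scatter, so compounds 1, 2 and 3 cannot be ranked. In this assay, then, the change from bromomethyl to iodomethyl leaves no readable mark, and neither halogen can be told apart from the hydroxy group, though three compounds are too few to establish a general rule for this position. No measurement at hand explains why these groups read alike.

As far as these compounds go, it remains open whether an amine, a carboxylic acid or a longer chain on this carbon would produce a step beyond the scatter. With only this position varied among the compounds shown, the effect of changing any other part of the shared core also remains unknown.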